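A few compounds are considered here, and "the series" means these few. Any claim that something is new, unique, unknown or untested is made for them only; others in the source may bear on it.

Compound 3 `COc1ccc(F)cc1CNCCCNc1ccnc2cc(CC(C)C)ccc12` gives 9.47 in a physicochemical assay for acid dissociation, level with compound 2 and, with it, the highest of the three numbers. Compound 2 `COc1ccc(F)cc1CNCCCNc1ccnc2cc(Cc3cc(C)cc(C)c3)ccc12` gives 9.47 and compound 1 `COc1ccc(Oc2ccc3c(NCCCNCc4cc(F)ccc4OC)ccnc3c2)cc1` gives 9.28; the gaps are small, since no change at the digits printed from compound 2 to compound 3 (within the scatter) and a number 0.19 log units higher from compound 1 to compound 3 (within the scatter). Compound 4 `COc1ccc(F)cc1CNCCCNc1ccnc2cc(Cc3ccc(F)cc3)ccc12` differs from compound 3 by 4-fluorophenyl in place of isopropyl on a saturated chain carbon bound to an aromatic carbon. The nearest guide is the swap on the same chain carbon, where no change at the digits printed from compound 2 to compound 3 (within the scatter); the changes at the other aromatic carbon, a number 0.19 log units higher from compound 1 to compound 2 (within the scatter) and a number 0.19 log units higher from compound 1 to compound 3 (within the scatter), are also small. For compound 4 a step of no change at the digits printed from compound 3 to compound 4 (within the scatter) is therefore expected, nothing beyond the scatter. Compound 4 is estimated at 9.47, with a range from 9.2 to 9.75.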

Compound 4, acid dissociation constant: 9.47
Estimate against measurement, compound 4: no gap at the digits printed, within the range that was stated.
By their numbers in this assay, from the lowest: compounds 1, 2, 3 and 4 (each within the scatter of the next).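

In this assay, 4-fluorophenyl in place of isopropyl on a saturated chain carbon bound to an aromatic carbon gives no change at the digits printed from compound 3 to compound 4 (within the scatter), and 4-fluorophenyl in place of 3,5-dimethylphenyl gives no change at the digits printed from compound 2 to compound 4 (within the scatter). A fluorine-bearing ring now joins isopropyl and 3,5-dimethylphenyl at this carbon with no step beyond the scatter, and the change on an aromatic carbon likewise gives a number 0.19 log units higher from compound 1 to compound 4 (within the scatter). Nothing available explains why these numbers stay so close. The compounds shown leave open whether an amine or a carboxylic acid on this chain carbon would give a step beyond the scatter.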